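Toward a Pyrrolidine Tertiary Amide in a Kinase Series

The compounds below may be only part of what the source reports. "The series", "measured", "known", "first", "only" and "open" are said of these compounds alone.

Compound 1 `CC(=O)N1CCC(NC(=O)c2ccncc2Nc2cc(-c3ccc4ccn(C)c4c3)c3nccnc3c2)CC1` gives 31300 nM in an assay on lysate for inhibition of 6-phosphofructo-2-kinase/fructose-2,6-bisphosphatase 3 (Homo sapiens), with stated times of 0.5 min and 45 min; on this read-out higher numbers stand for weaker inhibition and lower numbers for stronger inhibition.
Compound 2 `CN1CC(NC(=O)c2ccncc2Nc2cc(-c3ccc4ccn(C)c4c3)c3nccnc3c2)C1` gives 9190 nM in this assay.
Compound 3 `CC(=O)N1CC(CNC(=O)c2ccncc2Nc2cc(-c3ccc4ccn(C)c4c3)c3nccnc3c2)C1` reaches only a limit, > 100000 nM, in this assay.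

Compound 3 therefore stands apart: its result is not a number but the limit of this assay (the limit of > 100000 nM in this assay, at which 1 of the 3 values shown sits), and on the steps shown it is the weakest of the three. Compound 4 `CN1CCC(N(C)C(=O)c2ccncc2Nc2cc(-c3ccc4ccn(C)c4c3)c3nccnc3c2)C1` differs from compound 3 in one place: methyl(1-methylpyrrolidin-3-yl)amino in place of ((1-acetylazetidin-3-yl)methyl)amino on a carbonyl carbon. Among the measured compounds shown here, two measured steps bear on leaving the (1-acetylazetidin-3-yl)methyl group behind: an at least 10-fold higher number from compound 2 to compound 3 (1.03 log units; beyond the scatter), and an at least 3.1-fold higher number from compound 1 to compound 3 (0.50 log units; beyond the scatter). Read backwards, both point toward stronger inhibition when that group is removed. For the measured compounds named here, compound 4 resembles compound 2 in carrying a 1-methyl-bearing ring directly on the amide-type nitrogen, while the amide hydrogen is replaced by a methyl, a change for which no measured step exists. The step expected from compound 3 to compound 4 is thus an at least 5.0-fold lower number from compound 3 to compound 4 (0.69 log units; beyond the scatter), tempered by compound 3 being only a limit. Compound 4 is expected to give about 20000 nM, within 4000 nM to 100000 nM.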

Compound 4, half-maximal inhibitory concentration: 39700 nM
Beside the measured number, compound 4's estimate is 2.0-fold (0.30 log units) below it, within the range that was stated.
By their numbers in this assay, from the lowest: compound 2; then compounds 1 and 4 (each within the scatter of the next). At a limit, above all of these: compound 3.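

Compound 3 is held only at a limit, not a number: the limit of > 100000 nM in this assay, at which 1 of the 4 values shown sits.

Even so, the change on this carbonyl carbon gives an at least 2.5-fold lower number from compound 3 to compound 4 (0.40 log units; beyond the scatter), which shows that a group with no hydrogen-bond donor at this place can still return a real number. The other two steps read a 4.3-fold higher number from compound 2 to compound 4 (0.64 log units; beyond the scatter), and a 1.3-fold higher number from compound 1 to compound 4 (0.10 log units; within the scatter), so this tertiary amide falls short of compound 2 but cannot be told apart from compound 1.

The step from compound 2 changes the ring and adds the methyl on the amide nitrogen together, which leaves open how much each part contributes. Also open, as far as these compounds go, is what a primary amine or a carboxylic acid on the pyrrolidine ring, in place of its 1-methyl group, would do to the number.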